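Carbamate to urea at the carbonyl: morpholine replaces phenoxy

This account rests on a few compounds, and the source may have more. Where it says the series, first, only, none or still open, it means among the compounds named here.

Compound 2 `CN(C)c1ccc(-c2cccc(NC(=O)Oc3ccccc3)c2)cc1` gives 75% in an assay on COS-7 cells for inhibition of patatin-like phospholipase domain-containing protein 2 (Mus musculus), tested at 200 uM (a higher number here means more inhibition at the concentration tested (going by the name of the read-out), a lower number less inhibition), the lowest of the two numbers; the nearest is compound 1 `COC(=O)Nc1cccc(-c2ccc(N(C)C)cc2)c1` with 95%. Compound 3 `CN(C)c1ccc(-c2cccc(NC(=O)N3CCOCC3)c2)cc1` differs from compound 2 by morpholin-4-yl in place of phenoxy on a carbonyl carbon. Going by the values given here, the only measured step, a number 20 percentage points lower from compound 1 to compound 2 (beyond the scatter), concerns the same carbonyl position but a different exchange, so it bears on compound 3 only loosely. The exchange here, like that step, alters the group on the carbonyl carbon, so a modest move either way is possible. Compound 3 is expected to come out near compound 2, at 80% (range 55% to 98%), a step of a number 5 percentage points higher from compound 2 to compound 3 (within the scatter) being the estimate.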

Compound 3, a percentage reported as inhibition, at one concentration (the size of the read-out at that concentration, not a potency): 31%
Estimate against measurement, compound 3: 49 percentage points above; measured number outside the range, below it.
By their numbers in this assay, from the lowest: compound 3; then compound 2; then compound 1.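

On the carbonyl carbon, the exchange to morpholin-4-yl gives a number 44 percentage points lower from compound 2 to compound 3 (beyond the scatter) and a number 64 percentage points lower from compound 1 to compound 3 (beyond the scatter) in this assay; both steps are large, whereas a number 20 percentage points lower from compound 1 to compound 2 (beyond the scatter) is modest. This position therefore responds far more to the entry of morpholin-4-yl than to phenyl replacing methyl on the oxygen, with methoxy and phenoxy both standing above morpholin-4-yl. No measurement at hand accounts for the drop.

On these data alone, whether the drop follows the nitrogen on the carbonyl carbon or the morpholine ring itself remains open. Piperidin-1-yl or dimethylamino at this place would separate the two.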